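The source may report more compounds than this note shows. Statements on the series, on what has been measured and on what is new or still open speak of the compounds shown alone.

Of the compounds shown here, two have been tested so far. Compound 1 `Clc1ccccc1-c1nnc(COc2ccc(-c3ccccc3)cc2)o1` and compound 2 `CCCCn1c(S)nnc1COc1ccc(-c2ccccc2)cc1` share the same core with a biphenyl-bearing ether arm. In a functional assay on the whole organism (strain Wistar) for inhibition, with Rattus norvegicus as the target, read by paw edema, with a stated time of 4 h, at a dose of 10 mg/kg by the oral route (a lower number here means less inhibition, a higher number more inhibition at the dose given (going by the name of the read-out)), compound 1 gives 63.6%, while compound 2 gives 81.8%. Compound 2 thus stands highest of the two numbers, and the gap down to compound 1, its nearest neighbour, lies beyond the usual scatter of repeated measurements.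

Compound 3 `Cc1ccccc1-n1c(S)nnc1COc1ccc(-c2ccccc2)cc1` has not yet been measured. Compared with compound 2, the change is 2-methylphenyl in place of butyl on an aromatic nitrogen. Within the data shown here, no measured pair shows the effect of such a change, so the step to compound 3 can only be guessed; a modest fall, still within a range that overlaps the value of compound 2, seems the most likely outcome. Compound 3 is therefore expected to reach about 70% in this assay, with a plausible range of 52% to 86%. The expected step of a number 11.8 percentage points lower from compound 2 to compound 3 (beyond the scatter) is small and downward.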

Compound 3, a percentage reported as inhibition, in the whole organism at one dose (the size of the read-out at that dose, not a potency): 59.1%
Estimate against measurement, compound 3: 10.9 percentage points above; the measured number falls inside the stated range.
By their numbers in this assay, from the lowest: compounds 3 and 1 (each within the scatter of the next); then compound 2.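

Among these compounds, this pair gives the first direct reading of the group on the aromatic nitrogen, and in this assay the position is clearly sensitive to what it carries: 2-methylphenyl in place of butyl gives a step (a number 22.7 percentage points lower from compound 2 to compound 3 (beyond the scatter)). For this one pair at this one dose, the butyl chain with no ring therefore goes with the higher inhibition, and the larger group with one six-membered aromatic ring goes with the lower. Nothing available explains this step.

A single pair cannot show whether the fall goes with the aromatic ring itself or with its methyl group, and an unsubstituted phenyl on the same nitrogen would separate the two. On these data alone, how the number runs along other chains, such as propyl or hexyl, also remains open.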